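Trifluoro substitution on the phenoxy group of compound 3

The source may hold more compounds than are shown below. What is called first, only, known or untested is meant among the compounds shown, and "the series" means these compounds.

The shared core of compound 1 `CC(C)[C@H](NC(=O)COc1cccc2ccccc12)C(=O)N[C@@H](CC(=O)O)C(=O)COc1ccc(Oc2ccc(C(F)(F)F)cc2)cc1` carries a phenoxy ketone whose aryl group varies. In a functional assay on Jurkat cells (Homo sapiens) (on this read-out higher numbers stand for weaker inhibition and lower numbers for stronger inhibition), compound 1 gives 9300 nM. Compound 2 `CC(=O)Nc1cccc(OCC(=O)[C@H](CC(=O)O)NC(=O)[C@@H](NC(=O)COc2cccc3ccccc23)C(C)C)c1` reaches only the limit of this assay, > 100000 nM. Compound 3 `CC(C)[C@H](NC(=O)COc1cccc2ccccc12)C(=O)N[C@@H](CC(=O)O)C(=O)COc1ccccc1F` likewise gives only the limit, > 100000 nM. Among the compounds with values here, the one step measured, a step that the two limits leave unreadable from compound 2 to compound 3, is therefore unreadable, and the position of compound 3 is known only as that limit (the limit of > 100000 nM in this assay, at which 2 of the 3 values shown sit). Compound 4 `CC(C)[C@H](NC(=O)COc1cccc2ccccc12)C(=O)N[C@@H](CC(=O)O)C(=O)COc1c(F)cc(F)cc1F` differs from compound 3 by 2,4,6-trifluorophenyl in place of 2-fluorophenyl on an oxygen on a saturated carbon. Within the data shown here, no measured step bears on this change, so no shift beyond the scatter is anticipated, and compound 4 is expected to remain near the limit, with an estimated step of a number no higher from compound 3 to compound 4 (the limit leaves the size open). Compound 4 is estimated at 100000 nM, within 30000 nM to 300000 nM.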

Compound 4, half-maximal inhibitory concentration: 6840 nM
Estimate against measurement, compound 4: 15-fold (1.16 log units) above; the measured number lies below the stated range.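

In this assay, 2,4,6-trifluorophenyl in place of 2-fluorophenyl gives an at least 14-fold lower number from compound 3 to compound 4 (1.16 log units; beyond the scatter), and in place of 3-acetamidophenyl it gives an at least 14-fold lower number from compound 2 to compound 4 (1.16 log units; beyond the scatter). Within the data shown here, at this position, then, a phenyl group carrying only fluorine can bring a compound off the limit, which the earlier compounds did not show. Both steps start from a limit, so their full size stays open: the limit of > 100000 nM in this assay, at which 2 of the 4 values shown sit.

Which of the added fluorines matters remains open, as does whether chlorine or a methoxy group in their place would do the same.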